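This account rests on a few compounds, and the source may have more. Where it says the series, first, only, none or still open, it means among the compounds named here.

In an ADME assay on HepG2 cells (Homo sapiens) for cytotoxicity, read by CellTiter-Glo and resazurin assay, with a stated time of 72 h (on this read-out lower numbers stand for an effect already at smaller amounts and higher numbers for an effect only at larger amounts of compound), two compounds have been tested, and both ended at the ceiling of the assay. Compound 1, `CC(=O)c1cccc(-c2ccc(C(=O)N(Cc3cccc(OCCCCCC(=O)O)c3)C(C)C)cc2)c1`, gives > 26000 nM in this assay, which is a limit rather than a number. Compound 2, `CC(C)N(Cc1cccc(OCCCCCC(=O)O)c1)C(=O)c1ccc(-c2cccc(O)c2)cc1`, gives > 26000 nM in this assay, again a limit and not a number. The step that the two limits leave unreadable from compound 1 to compound 2 cannot be read: the two limits hide its size. Compound 2 thus stands where the limit of > 26000 nM in this assay, at which 2 of the 2 values shown sit, puts it, together with compound 1. The next compound, compound 3, `COc1ccc(F)c(-c2ccc(C(=O)N(Cc3cccc(OCCCCCC(=O)O)c3)C(C)C)cc2)c1`, carries a different exchange: 2-fluoro-5-methoxyphenyl in place of 3-hydroxyphenyl on an aromatic carbon, on an aromatic carbon of a six-membered aromatic ring of carbon only, para to a large group. Within the data shown here, no measured step bears directly on this exchange; the only step known, a step that the two limits leave unreadable from compound 1 to compound 2, is unreadable and gives no size to compare. With both measured compounds sitting at the limit, compound 3 is expected to sit there as well, with a step that the limit leaves unreadable from compound 2 to compound 3 estimated to lie within the scatter. The estimate for compound 3 in this assay is 40000 nM, with a range from 15000 nM to 150000 nM.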

Compound 3, half-maximal effective concentration: > 26000 nM
Compound 3: only a limit was reported; the forecaster's own chance of this, stated with the estimate: 85%; the middle value does not contradict the limit.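

In this assay compound 3 gives > 26000 nM and this is a limit, not a number. The steps from compound 1 and from compound 2 to compound 3 cannot be read. Still open, from the compounds shown here alone, is how these three compounds compare in this assay and at what concentration, if any, each would show an effect on the cells.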